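A few compounds are considered here, and "the series" means these few. Any claim that something is new, unique, unknown or untested is made for them only; others in the source may bear on it.

Working notes on the series

For the measured compounds named here, compound 2 `CC[C@@H](C)[C@H](NC(=O)c1ccc(C(CC)(CC)c2ccc(OCC(=O)C(C)(C)C)c(C)c2)n1CC)C(=O)O` stands lowest of the two numbers so far in an assay on HL-60 cells for agonist activity at vitamin D3 receptor (Homo sapiens), read by microscopy, with a stated time of 96 h (on this read-out lower numbers stand for an effect already at smaller amounts and higher numbers for an effect only at larger amounts of compound), where compound 2 gives 10 nM. Its nearest neighbour is compound 1 `C#CCNC(=O)c1ccc(C(CC)(CC)c2ccc(OCC(=O)C(C)(C)C)c(C)c2)n1CC`, which in this assay gives 2200 nM; the change from the propargyl group to the 1-carboxy-2-methylbutyl group on the amide-type nitrogen brought a 220-fold lower number from compound 1 to compound 2 (2.34 log units; beyond the scatter).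

The next compound, compound 3 `CCn1c(C(=O)OCc2ccccn2)ccc1C(CC)(CC)c1ccc(OCC(=O)C(C)(C)C)c(C)c1`, departs from compound 2 at the same carbonyl carbon: (pyridin-2-yl)methoxy in place of (1-carboxy-2-methylbutyl)amino on a carbonyl carbon. The amide-type nitrogen and its carboxylic acid both leave; an ester-type oxygen bearing a pyridine ring enters.

Going by the values given here, only one measured step bears on this position, and it is a 220-fold lower number from compound 1 to compound 2 (2.34 log units; beyond the scatter); it shows that what hangs from this carbonyl can move the number by a large amount. Among the compounds with values here, compound 3, like compound 1, carries no carboxylic acid at this position, so the number is expected to move back up toward that of compound 1, though the pyridine ring has no measured precedent here. The expected step is an 80-fold higher number from compound 2 to compound 3 (1.90 log units; beyond the scatter), and compound 3 is estimated at 800 nM with a range of 150 nM to 5000 nM.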

Compound 3, half-maximal effective concentration: > 50000 nM
Compound 3 was reported as a limit; the forecaster's own chance of this, stated with the estimate: 10%; middle value at least 62-fold (1.79 log units) away from the limit.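

Compound 3 is reported in this assay only as a limit, not as a number: the limit of > 50000 nM in this assay, at which 1 of the 3 values shown sits.

With (pyridin-2-yl)methoxy in place of (1-carboxy-2-methylbutyl)amino on the carbonyl carbon, the result is an at least 5000-fold higher number from compound 2 to compound 3 (3.69 log units; beyond the scatter), a far larger move at this position than the one between the two amides. With the same group in place of propargylamino, the result is an at least 22-fold higher number from compound 1 to compound 3 (1.35 log units; beyond the scatter), so two compounds without a carboxylic acid at this position still stand apart beyond the scatter, and the lack of that acid does not by itself fix the number here.

Compound 3 changes the amide-type nitrogen to an ester-type oxygen and brings in the pyridine ring in one step, so these notes cannot assign the step to either one; a (pyridin-2-yl)methylamino group on the same carbonyl carbon would separate the two. Going by these compounds, it also remains open whether the low number of compound 2 rests on its carboxylic acid or on its branched chain, a question that a plain 2-methylbutylamino group or a carboxymethylamino group would address.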